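This account rests on a few compounds, and the source may have more. Where it says the series, first, only, none or still open, it means among the compounds named here.

In a functional assay on Bel-7402 cells (Homo sapiens) for cytotoxicity, read by MTT assay (a lower number here means a stronger inhibitor, a higher number a weaker inhibitor), compound 3 `CCn1cc(C(=O)Nc2ccccc2N)c(=O)c2cc(F)c(N3CCNC(C)C3)c(F)c21` gives 4800 nM and compound 1 `CCn1cc(C(=O)Nc2ccccc2)c(=O)c2cc(F)c(N3CCNC(C)C3)c(F)c21` gives 6000 nM. These two lie within the scatter of each other, as a 1.3-fold lower number from compound 1 to compound 3 (0.10 log units; within the scatter) shows. Compound 2 `CCn1cc(C(=O)Nc2ccccc2O)c(=O)c2cc(F)c(N3CCNC(C)C3)c(F)c21` gives > 50000 nM, which is a limit and not a number. The hydroxy change stands apart: an at least 8.3-fold higher number from compound 1 to compound 2 (0.92 log units; beyond the scatter), and an at least 10-fold lower number from compound 2 to compound 3 (1.01 log units; beyond the scatter).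

Compound 4 `CCn1cc(C(=O)Nc2ccc(OC)cc2)c(=O)c2cc(F)c(N3CCNC(C)C3)c(F)c21` differs from compound 3 by 4-methoxyphenyl in place of 2-aminophenyl on an amide-type nitrogen. For the measured compounds named here, no measured step covers this exact change. The amino step from compound 1 is the closest guide and stayed within the scatter, while the hydroxy step from compound 1 leaves some risk of a higher number. The expected step is a 1.7-fold higher number from compound 3 to compound 4 (0.22 log units; within the scatter), with no change beyond the scatter expected. Compound 4 is estimated at 8000 nM, with an expected range of 2500 nM to 30000 nM.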

Compound 4, half-maximal inhibitory concentration: 5400 nM
Estimate against measurement, compound 4: 1.5-fold (0.17 log units) above, within the range that was stated.
By their numbers in this assay, from the lowest: compounds 3, 4 and 1 (each within the scatter of the next). At a limit, above all of these: compound 2.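

In this assay, 4-methoxyphenyl on the amide-type nitrogen stays level with 2-aminophenyl (a 1.1-fold higher number from compound 3 to compound 4 (0.05 log units; within the scatter)) and with the plain phenyl of compound 1 (a 1.1-fold lower number from compound 1 to compound 4 (0.05 log units; within the scatter)), so a substituent on this ring need not raise the number. Among the oxygen-bearing groups, the loss seen with 2-hydroxyphenyl does not carry over to 4-methoxyphenyl (an at least 9.2-fold lower number from compound 2 to compound 4 (0.96 log units; beyond the scatter)). The value of compound 2 is a limit, not a number: (the limit of > 50000 nM in this assay, at which 1 of the 4 values shown sits).

Still open, going by these compounds, is whether 2-methoxyphenyl or 4-hydroxyphenyl would follow compound 2 or compound 4. A carboxylic acid on this ring also remains untested in the compounds shown.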